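The compounds below may be only part of what the source reports. "The series", "measured", "known", "first", "only" and "open" are said of these compounds alone.

Measured in a functional assay on A549 cells (Homo sapiens) for antiproliferative activity, read by MTT assay, with a stated time of 72 h; on this read-out higher numbers stand for weaker inhibition and lower numbers for stronger inhibition:
Compound 1, `C=C(Cl)C(=O)Nc1cc(Nc2ncc(C#N)c(-c3cn(C)c4ccccc34)n2)c(OC)cc1N(C)CCN(C)C`: 133 nM
Compound 2, `CC/C=C\C(=O)Nc1cc(Nc2ncc(C#N)c(-c3cn(C)c4ccccc34)n2)c(OC)cc1N(C)CCN(C)C`: 162 nM
Compound 3, `C=C(Cl)C(=O)Nc1cc(Nc2nc(C)cc(-c3cn(C)c4ccccc34)n2)c(OC)cc1N(C)CCN(C)C`: 1730 nM

Compound 1 and compound 2 share one core and differ in a single place: but-1-en-1-yl in place of 1-chloroethenyl on a carbonyl carbon. This change gave a 1.2-fold higher number from compound 1 to compound 2 (0.09 log units; within the scatter), so the values of compound 1 and compound 2 cannot be told apart. Compound 3 carries a different core; the difference between the two cores is not broken down here. In this assay compound 3 gives 1730 nM, which lies beyond the scatter from both compound 1 and compound 2, so compound 3 is the weakest of the three measured.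

Compound 4, `CC/C=C\C(=O)Nc1cc(Nc2nc(C)cc(-c3cn(C)c4ccccc34)n2)c(OC)cc1N(C)CCN(C)C`, has not yet been measured. It relates to compound 3 as compound 2 relates to compound 1: but-1-en-1-yl in place of 1-chloroethenyl on a carbonyl carbon. The place is the same word for word in both pairs, so this is the same change. On the strength of the earlier step of a 1.2-fold higher number from compound 1 to compound 2 (0.09 log units; within the scatter), which stayed within the scatter, a step of similar size is expected for compound 4: a 1.2-fold higher number from compound 3 to compound 4 (0.06 log units; within the scatter). Within the data shown here, this rests on compound 1 and compound 2 alone, as only one such pair has been measured. Compound 4 is therefore estimated at 2000 nM, with an expected range from 900 nM to 4500 nM.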

Compound 4, half-maximal inhibitory concentration: 1090 nM
The estimate for compound 4 lay 1.8-fold (0.26 log units) above the measured number, within the range that was stated.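

In this assay, putting but-1-en-1-yl in place of 1-chloroethenyl on a carbonyl carbon gave a 1.6-fold lower number from compound 3 to compound 4 (0.20 log units; within the scatter), so these two values cannot be told apart. Set beside the earlier step, the same change reads alike on both cores, with no difference that stands out from the scatter: the same change on two cores in this assay, a 1.2-fold higher number (0.09 log units; within the scatter) from compound 1 to compound 2 and a 1.6-fold lower number (0.20 log units; within the scatter) from compound 3 to compound 4, 1.9-fold (0.29 log units) apart, within the scatter of two such steps. Among these compounds, this shows that, on these two cores, the exchange left the number within the scatter, but with only two pairs it does not show that the same would hold on any other core, and it says nothing about why the two groups read alike.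

The compounds shown leave open how other groups on the same carbonyl carbon would read, such as a plain ethenyl, a longer alkenyl chain or a chain carrying an amine. They also leave open which part of the difference between the two cores matters in this assay.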